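This account rests on a few compounds, and the source may have more. Where it says the series, first, only, none or still open, it means among the compounds named here.

Measured in a functional assay on MCF7 cells (Homo sapiens) for antiproliferative activity, read by MTT assay, with a stated time of 48 h; a lower number here means a stronger inhibitor, a higher number a weaker inhibitor:
- compound 1 `CCOc1cc(-c2ccc3[nH]ccc3c2)cn2c(-c3cc(OC)c(OC)c(OC)c3)nnc12`: 284 nM
- compound 2 `COc1cc(-c2nnc3c(OC(C)C)cc(-c4ccc5[nH]ccc5c4)cn23)cc(OC)c1OC`: 1020 nM

Of the two measured compounds, compound 2 has the higher number, at 1020 nM. Among the measured compounds shown here, its only neighbour on the scale is compound 1, at 284 nM.

The next compound is compound 3 `COc1cc(-c2nnc3c(OC4COC4)cc(-c4ccc5[nH]ccc5c4)cn23)cc(OC)c1OC`, with this change from compound 2: oxetan-3-yl in place of isopropyl on an oxygen on an aromatic ring. Here, oxetan-3-yl takes the place of isopropyl on an oxygen on an aromatic ring.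

For the measured compounds named here, one measured step bears on this change: a 3.6-fold higher number from compound 1 to compound 2 (0.56 log units; beyond the scatter). This modest step, which lies beyond the scatter, involves the same substituent on that oxygen, but it is not the same change. Going by the values given here, no measured compound carries a ring at this place, so the evidence is thin.

A move toward a lower number in this assay is expected, smaller than the measured step and possibly no larger than the scatter. The expected step is a 1.7-fold lower number from compound 2 to compound 3 (0.23 log units; within the scatter). The estimate for compound 3 is 600 nM, with an expected range of 200 nM to 1800 nM.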

Compound 3, half-maximal inhibitory concentration: 2470 nM
Compound 3: the middle estimate sits 4.1-fold (0.61 log units) below what was measured, and the stated range ends below it.
By their numbers in this assay, from the lowest: compound 1; then compound 2; then compound 3.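

In this assay, oxetan-3-yl in place of isopropyl on this oxygen gives a 2.4-fold higher number from compound 2 to compound 3 (0.38 log units; beyond the scatter), so the first ring at this place moves the number up, not down. Oxetan-3-yl in place of ethyl gives an 8.7-fold higher number from compound 1 to compound 3 (0.94 log units; beyond the scatter), and the three groups on this oxygen now run ethyl, isopropyl, oxetan-3-yl from the lowest number to the highest, with every step among them beyond the scatter and no compound of the three against that order. No measured property of these compounds is available to account for this rise.

A ring and a ring oxygen enter together in compound 3, so the compounds shown do not separate the two, and cyclobutyl on the same oxygen would place a four-membered ring there without the ring oxygen. Also open, on these data alone, is whether methyl on this oxygen would extend the order to a number lower than that of compound 1, or whether a longer chain such as 2-methoxyethyl would follow isopropyl and oxetan-3-yl upward.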